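Replacing the side chain of compound 2

This account rests on a few compounds, and the source may have more. Where it says the series, first, only, none or still open, it means among the compounds named here.

Compound 1 `O=C1c2c[n+]([O-])c3ccccc3c2C(=O)c2c1c1ccccc1n2Cc1cn(CC(O)CO)nn1`: 250 nM
Compound 2 `O=C1c2c[n+]([O-])c3ccccc3c2C(=O)c2c1c1ccccc1n2Cc1cn(C[C@@H](O)CO)nn1`: 190 nM
Compound 3 `O=C1c2c[n+]([O-])c3ccccc3c2C(=O)c2c1c1ccccc1n2CCCN1CCC(O)CC1`: not yet measured

In a functional assay on HCT-116 cells (Homo sapiens) for cytotoxicity, read by MTT assay, with a stated time of 72 h (on this read-out higher numbers stand for weaker inhibition and lower numbers for stronger inhibition), compound 2 gives 190 nM, within the scatter of compound 1. Compound 3 carries 2-(4-hydroxypiperidin-1-yl)ethyl in place of 1-(2,3-dihydroxypropyl)-1H-1,2,3-triazol-4-yl on a saturated chain carbon bound to an aromatic nitrogen. For the measured compounds named here, the only measured step, a 1.3-fold lower number from compound 1 to compound 2 (0.12 log units; within the scatter), rests on the fact that one of compounds 1 and 2 is drawn with a defined configuration and the other without, at the place where they differ and leaves the side chain's groups unchanged, so it gives no size for this exchange. No change beyond the scatter is therefore expected in this assay, though with wide uncertainty. The expected step is a 1.1-fold lower number from compound 2 to compound 3 (0.05 log units; within the scatter). For compound 3 the estimated value is 170 nM, with an expected range from 50 nM to 600 nM.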

Compound 3, half-maximal inhibitory concentration: 190 nM
Compound 3: middle estimate off by 1.1-fold (0.05 log units), on the low side, and the stated range covers the measured number.
By their numbers in this assay, from the lowest: compounds 2, 3 and 1 (each within the scatter of the next).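

In this assay, the exchange of 1-(2,3-dihydroxypropyl)-1H-1,2,3-triazol-4-yl for 2-(4-hydroxypiperidin-1-yl)ethyl gives no change at the digits printed from compound 2 to compound 3 (within the scatter), and likewise a 1.3-fold lower number from compound 1 to compound 3 (0.12 log units; within the scatter). On a saturated chain carbon bound to an aromatic nitrogen, a six-membered non-aromatic ring thus reads like the five-membered aromatic ring, which the stereo pair alone could not show. No available evidence bears on why these side chains read alike. Still open, as far as these compounds go, is whether an unsubstituted piperidine, a morpholine or a carboxylic acid at this place would read the same.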